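Ethynyl in place of phenyl on a limit-bound series

The compounds below may be only part of what the source reports. "The series", "measured", "known", "first", "only" and "open" are said of these compounds alone.

The series shares one core, carried by compound 1 `COc1ncnc2c1c(-c1ccccc1)cn2[C@@H]1O[C@H](CO)[C@@H](O)[C@H]1O`, compound 2 `CNc1ncnc2c1c(-c1ccccc1)cn2[C@@H]1O[C@H](CO)[C@@H](O)[C@H]1O` and compound 3 `CSc1ncnc2c1c(-c1ccccc1)cn2[C@@H]1O[C@H](CO)[C@@H](O)[C@H]1O`, each run in an ADME assay on BJ cells (Homo sapiens), read by MTT assay, with a stated time of 72 h; on this read-out lower numbers stand for stronger inhibition and higher numbers for weaker inhibition. In this assay compound 1 gives > 100000 nM, which is a limit of the assay and not a number. Compound 2 likewise gives only a limit, > 100000 nM. Compound 3 too stands at a limit, > 100000 nM. Compound 2 thus has no position on a numeric scale here; it sits, with the other two, at the limit of > 100000 nM in this assay, at which 3 of the 3 values shown sit. The measured steps a step that the two limits leave unreadable from compound 1 to compound 2, a step that the two limits leave unreadable from compound 1 to compound 3 and a step that the two limits leave unreadable from compound 2 to compound 3 are all unreadable for that reason, and none of them gives a size or a direction.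

Compound 4 `C#Cc1cn([C@@H]2O[C@H](CO)[C@@H](O)[C@H]2O)c2ncnc(NC)c12` is not yet measured. It differs from compound 2 as follows: ethynyl in place of phenyl on an aromatic carbon. For the measured compounds named here, none of the measured steps concerns this change; they all exchange methoxy, methylamino and methylsulfanyl, and all were unreadable. No direction and no size beyond the scatter can therefore be drawn from them. The expected step from compound 2 is a number no higher from compound 2 to compound 4 (the limit leaves the size open), meaning no readable change is anticipated. Compound 4 is estimated at 100000 nM, with a range from 20000 nM to 500000 nM, and most likely the assay again returns only a limit.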

Compound 4, half-maximal inhibitory concentration: 86000 nM
Estimate against measurement, compound 4: 1.2-fold (0.07 log units) above, and the stated range covers the measured number.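

In this assay compound 4 gives 86000 nM, a number on the scale, whereas the steps among methoxy, methylamino and methylsulfanyl cannot be read. Compound 2 stands at > 100000 nM, which is a limit of the assay and not a number, and the same limit covers most of the series: the limit of > 100000 nM in this assay, at which 3 of the 4 values shown sit. Ethynyl in place of phenyl, on the aromatic carbon two ring bonds from the ring nitrogen, gives an at least 1.1-fold lower number from compound 2 to compound 4 (0.06 log units; that floor lies within the scatter), so this position yields a step with a floor, but that floor alone does not separate the two compounds, and the true size of the change stays unknown.

The compounds shown leave open whether ethynyl also gives a number when methoxy or methylsulfanyl takes the place of methylamino on the shared core. They also leave open how this position reads with a longer chain such as propynyl, with an amine such as aminomethyl, or with a carboxylic acid, and whether any such group moves the number further from the limit.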